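Swapping nitrile for acetamido in a small antagonist series

The source may hold more compounds than are shown below. What is called first, only, known or untested is meant among the compounds shown, and "the series" means these compounds.

The series shares the core of compound 1 `Cc1cc(COc2ccccc2)nc(-c2ccccn2)n1`, which in a functional assay on cells for antagonist activity at Free fatty acid receptor 1 (Homo sapiens), read by TR-FRET and inositol phosphate accumulation, with a stated time of 2 h (on this read-out lower numbers stand for stronger inhibition and higher numbers for weaker inhibition), gives 794 nM. Compound 2 `Cc1cc(COc2ccccc2Cl)nc(-c2ccccn2)n1` gives 316 nM in this assay, and compound 3 `Cc1cc(COc2ccccc2C#N)nc(-c2ccccn2)n1` gives 10000 nM, the highest of the three numbers. The change at this position from hydrogen to chloro produced the step of a 2.5-fold lower number from compound 1 to compound 2 (0.40 log units; beyond the scatter), whereas cyano produced the step of a 13-fold higher number from compound 1 to compound 3 (1.10 log units; beyond the scatter) and the step of a 32-fold higher number from compound 2 to compound 3 (1.50 log units; beyond the scatter). Compound 4 `CC(=O)Nc1ccccc1OCc1cc(C)nc(-c2ccccn2)n1` differs from compound 3 by acetamido in place of cyano on an aromatic carbon. Going by the values given here, no measured step involves acetamido, so the direction rests only on compound 3 sitting at the top, where a move toward lower numbers is the more likely outcome. Compound 4 is therefore expected to give 3000 nM, with a range from 700 nM to 10000 nM. The step of a 3.3-fold lower number from compound 3 to compound 4 (0.52 log units; beyond the scatter) is expected to be modest, toward stronger inhibition.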

Compound 4, half-maximal inhibitory concentration: > 39800 nM
Compound 4 gave a limit, no number; the forecaster's own chance of this, stated with the estimate: 25%; at least 13-fold (1.12 log units) between middle value and limit.
By their numbers in this assay, from the lowest: compound 2; then compound 1; then compound 3. At a limit, above all of these: compound 4.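

Compound 4 gives a limit, not a number: the limit of > 39800 nM in this assay, at which 1 of the 4 values shown sits. The change from cyano to acetamido moved further toward weaker inhibition, with an at least 3.9-fold higher number from compound 3 to compound 4 (0.59 log units; beyond the scatter), while the steps from the other two compounds are an at least 50-fold higher number from compound 1 to compound 4 (1.70 log units; beyond the scatter) and an at least 120-fold higher number from compound 2 to compound 4 (2.10 log units; beyond the scatter). Among the four groups at this position, only chloro gives a lower number than hydrogen, and now both cyano and acetamido give higher ones.

From the compounds shown here alone, how far compound 4 lies beyond its limit stays open. So does whether a methoxy group or an amine here would side with chloro or with acetamido.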